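Swapping 4-(trifluoromethyl)phenyl for 3-nitrophenyl on a shared core

The source may hold more compounds than are shown below. What is called first, only, known or untested is meant among the compounds shown, and "the series" means these compounds.

In a functional assay on SGC-7901 cells (Homo sapiens) for antiproliferative activity, read by MTT assay, with a stated time of 72 h (a lower number here means a stronger inhibitor, a higher number a weaker inhibitor), compound 3 `COc1cc(-n2cnc3ccc(-c4ccc(C(F)(F)F)cc4)cc32)cc(OC)c1OC` gives 890 nM, the lowest number of the three measured compounds. Compound 1 `CCOc1ccc(-c2ccc3ncn(-c4cc(OC)c(OC)c(OC)c4)c3c2)cc1` gives 2970 nM, and compound 2 `COc1ccccc1-c1ccc2ncn(-c3cc(OC)c(OC)c(OC)c3)c2c1` gives 5050 nM. The next compound, compound 4 `COc1cc(-n2cnc3ccc(-c4cccc([N+](=O)[O-])c4)cc32)cc(OC)c1OC`, carries 3-nitrophenyl in place of 4-(trifluoromethyl)phenyl on an aromatic carbon. Going by the values given here, the closest precedent is the exchange of one whole aryl group for another, a 5.7-fold lower number from compound 2 to compound 3 (0.75 log units; beyond the scatter). The change of ethoxy to trifluoromethyl gives a smaller step, a 3.3-fold lower number from compound 1 to compound 3 (0.52 log units; beyond the scatter). Between the two compounds lacking trifluoromethyl, the step is a 1.7-fold higher number from compound 1 to compound 2 (0.23 log units; within the scatter). So both measured compounds without the 4-(trifluoromethyl)phenyl group show higher numbers than compound 3, but neither carries a nitro group, so the size of the step remains uncertain. A modest rise is therefore expected, and the expected change is a 2.2-fold higher number from compound 3 to compound 4 (0.35 log units; beyond the scatter). For compound 4, the estimated value is 2000 nM, with an expected range from 700 nM to 5500 nM.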

Compound 4, half-maximal inhibitory concentration: 380 nM
Estimate against measurement, compound 4: 5.3-fold (0.72 log units) above; the measured number lies below the stated range.
By their numbers in this assay, from the lowest: compound 4; then compound 3; then compounds 1 and 2 (each within the scatter of the next).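

At this position of the shared core, this assay shows that the number can fall further than compound 3 had indicated (a 2.3-fold lower number from compound 3 to compound 4 (0.37 log units; beyond the scatter)), so 4-(trifluoromethyl)phenyl does not mark the low end and 3-nitrophenyl, with no trifluoromethyl group, gives the lowest number of the four. Going by these compounds alone, the exchange also widens the spread at this single position, against both 4-ethoxyphenyl (a 7.8-fold lower number from compound 1 to compound 4 (0.89 log units; beyond the scatter)) and 2-methoxyphenyl (a 13-fold lower number from compound 2 to compound 4 (1.12 log units; beyond the scatter)), the second being the only large step in the set. No measurement shown here explains why 3-nitrophenyl gives the lowest number.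

The exchange changes both the group and where it sits on the phenyl ring, and the compounds shown do not separate these two changes. On these data alone, whether an amine or a carboxylic acid in place of the nitro group would keep the number this low remains open.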